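This account rests on a few compounds, and the source may have more. Where it says the series, first, only, none or still open, it means among the compounds named here.

Of the compounds shown here, three sharing one core have been measured in a functional assay on DU-145 cells (Homo sapiens) for inhibition, read by trypan blue exclusion, with a stated time of 72 h; a lower number here means a stronger inhibitor, a higher number a weaker inhibitor. Compound 1 `Cn1c(=O)c(S(=O)(=O)c2ccc(C(=O)O)cc2)cc2cnc(Nc3ccc4[nH]ccc4c3)nc21`, which carries a carboxy group on an aromatic carbon, gives 10000 nM. Compound 2 `Cc1ccc(S(=O)(=O)c2cc3cnc(Nc4ccc5[nH]ccc5c4)nc3n(C)c2=O)cc1`, with methyl at that place, gives 750 nM, and compound 3 `Cn1c(=O)c(S(=O)(=O)c2ccc(Br)cc2)cc2cnc(Nc3ccc4[nH]ccc4c3)nc21`, with bromo there, gives 5000 nM. Compound 3 stands level with compound 1, the two being separated by a 2.0-fold lower number from compound 1 to compound 3 (0.30 log units; within the scatter). Compound 2 is set apart from it by a 6.7-fold higher number from compound 2 to compound 3 (0.82 log units; beyond the scatter).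

Compound 4 `Cn1c(=O)c(S(=O)(=O)Nc2ccc(F)cc2F)cc2cnc(Nc3ccc4[nH]ccc4c3)nc21` differs from compound 3 at the sulfonyl sulfur, where (2,4-difluorophenyl)amino stands in place of 4-bromophenyl: (2,4-difluorophenyl)amino in place of 4-bromophenyl on a sulfonyl sulfur. Within the data shown here, no measured step makes this change. All three exchange a group on an aromatic carbon and leave the attachment to the sulfonyl sulfur untouched, so they bear on it only indirectly. The largest, a 13-fold lower number from compound 1 to compound 2 (1.12 log units; beyond the scatter), shows how far a single exchange can move the number in this assay. With compound 3 at 5000 nM, far closer to compound 1 than to compound 2, a modest move towards a lower number seems the likelier outcome, though with wide uncertainty. The expected change is a 2.5-fold lower number from compound 3 to compound 4 (0.40 log units; beyond the scatter). For compound 4 the estimate is 2000 nM, with an expected range of 400 nM to 8000 nM.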

Compound 4, half-maximal inhibitory concentration: 5000 nM
Compound 4: the middle estimate sits 2.5-fold (0.40 log units) below what was measured, within the range that was stated.
By their numbers in this assay, from the lowest: compound 2; then compounds 3, 4 and 1 (each within the scatter of the next).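

In this assay, this is the first exchange shown at the attachment to the sulfonyl sulfur itself, and (2,4-difluorophenyl)amino in place of 4-bromophenyl gives no change at the digits printed from compound 3 to compound 4 (within the scatter) and so leaves the two compounds level. Replacing 4-carboxyphenyl at the same sulfur gives a 2.0-fold lower number from compound 1 to compound 4 (0.30 log units; within the scatter) and again leaves the pair level, whereas replacing 4-methylphenyl gives a 6.7-fold higher number from compound 2 to compound 4 (0.82 log units; beyond the scatter) and shows that compound 4 does not reach the number of compound 2, which stays apart from the other three compounds. No measurement at hand gives a reason for this outcome.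

The compounds shown leave open whether the amino link or the two fluorines decide the number at this sulfur, as the link and the fluorines enter together in compound 4. A (4-methylphenyl)amino group on the sulfonyl sulfur would test the link alongside the methyl group of compound 2, while a 2,4-difluorophenyl group on the same sulfur, or a non-aromatic amine such as morpholine, would separate the ring from the nitrogen.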